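The compounds below may be only part of what the source reports. "The series", "measured", "known", "first", "only" and "open" are said of these compounds alone.

Compound 3 `O=CN1CCN(c2ccc(Cl)cc2)C1=S` is the simplest of the three compounds measured in a functional assay on HT-29 cells (Homo sapiens) for inhibition, read by sulforhodamine B assay, with a stated time of 48 h (on this read-out higher numbers stand for weaker inhibition of growth and lower numbers for stronger inhibition of growth), and compound 3 gives 17200 nM. That is the lowest of the three numbers, yet the gaps to the others are small: compound 1 `N#C/C(=C\N1CCN(C(=O)c2ccco2)C1=S)C(=O)Nc1ccc(Cl)cc1` gives 21400 nM, and compound 2 `N#C/C(=C\N1CCN(C(=O)c2ccco2)C1=S)C(=O)c1ccccc1` gives 30500 nM, both within the usual scatter of compound 3. The only step measured between two of these compounds, a 1.4-fold higher number from compound 1 to compound 2 (0.15 log units; within the scatter), changes a group far from the shared core and stays within the scatter.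

Compound 4 `O=CN1CCN(c2ccc(Cl)c(Cl)c2)C1=S` differs from compound 3 by chloro in place of hydrogen on an aromatic carbon. Among the compounds with values here, no measured step adds a chloro group to the ring, so the one step on record bears on it only loosely, by showing that the small changes tried so far have not moved this assay beyond the scatter. The expectation for compound 4 is therefore a number close to that of compound 3, with a 1.1-fold lower number from compound 3 to compound 4 (0.03 log units; within the scatter), estimated at 16000 nM within a range of 7000 nM to 36000 nM.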

Compound 4, concentration for 50% growth inhibition: 19400 nM
Compound 4: the middle estimate sits 1.2-fold (0.08 log units) below what was measured; low and high end bracket the measured number.
By their numbers in this assay, from the lowest: compounds 3, 4, 1 and 2 (each within the scatter of the next).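

Putting a chloro group in place of hydrogen on the aromatic carbon ortho to the existing chloro group, and meta to a group of 8 heavy atoms, gives a 1.1-fold higher number from compound 3 to compound 4 (0.05 log units; within the scatter) in this assay. Within the data shown here, this is the first measured step at this ring position, as the earlier step concerned a different part of the molecule, and compound 3 and compound 4 cannot be told apart on this read-out. Nothing measured here offers an explanation for this result.

Still open, on these data alone, is whether a methoxy group, an amine or a carboxylic acid on this same aromatic carbon would give a step beyond the scatter. As far as these compounds go, it is also open whether chloro in place of hydrogen would give a similar result on the phenyl ring of compound 2.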